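Methylthiophene in Place of Methyl on the Ketone

A few compounds are considered here, and "the series" means these few. Any claim that something is new, unique, unknown or untested is made for them only; others in the source may bear on it.

compound 1 `COc1ccc(C(=O)c2sc(NC(C)C)c(C#N)c2N)cc1`: 4130 nM
compound 2 `CC(=O)c1sc(NC(C)C)c(C#N)c1N`: > 5000 nM
compound 3 `CC(C)Nc1sc(C(=O)c2cccnc2)c(N)c1C#N`: > 5000 nM

In an assay for inhibition of Maternal embryonic leucine zipper kinase (Homo sapiens), read by ADP-Glo, with a stated time of 0.5 h (a lower number here means a stronger inhibitor, a higher number a weaker inhibitor), compound 1 gives 4130 nM. Compound 2 gives only a limit of the assay, > 5000 nM. Compound 3 likewise gives only a limit, > 5000 nM. Compound 2 thus stands at the limit, and the step that the two limits leave unreadable from compound 2 to compound 3 cannot be read, since both values sit at the limit of > 5000 nM in this assay, at which 2 of the 3 values shown sit. Compound 4 `Cc1ccc(C(=O)c2sc(NC(C)C)c(C#N)c2N)s1` differs from compound 2 by 5-methylthiophen-2-yl in place of methyl on a carbonyl carbon. Among the compounds with values here, no measured step from compound 2 has a readable size, and compound 1 is the only compound with a number. The step of an at least 1.4-fold lower number from compound 2 to compound 4 (0.15 log units; that floor lies within the scatter) is therefore expected to be uncertain, with compound 4 possibly near the value of compound 1. Compound 4 is estimated at 3500 nM, within 1200 nM to 10000 nM.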

Compound 4, half-maximal inhibitory concentration: 494 nM
Compound 4: the middle estimate sits 7.1-fold (0.85 log units) above what was measured, outside the stated range (below it).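

In this assay, 5-methylthiophen-2-yl on the carbonyl carbon brings an at least 10-fold lower number from compound 2 to compound 4 (1.00 log units; beyond the scatter) in place of methyl, and an at least 10-fold lower number from compound 3 to compound 4 (1.00 log units; beyond the scatter) in place of pyridin-3-yl. Compound 3 also carries an aromatic ring at this place, yet its value remains a limit, > 5000 nM, so a ring alone does not bring the gain. Both step sizes are only floors: the limit of > 5000 nM in this assay, at which 2 of the 4 values shown sit.

The compounds shown do not separate the contribution of the ring sulfur from that of the ring methyl. From the compounds shown here alone, how a plain thiophen-2-yl or a 5-chlorothiophen-2-yl would read remains open.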